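Aryl versus benzyl on the amide nitrogen: compound 3

This account rests on a few compounds, and the source may have more. Where it says the series, first, only, none or still open, it means among the compounds named here.

Two members of the series have been measured in a functional assay (QGY7701 cells, Homo sapiens) for inhibition, read by MTT assay, with a stated time of 48 h; a lower number here means a stronger inhibitor, a higher number a weaker inhibitor. Among the measured compounds shown here, compound 2 (`Cc1ccc(CNC(=O)/C=C/c2coc3cc(O)ccc3c2=O)cc1`) gives 24900 nM and holds the only numerical value in the set. Compound 1 (`COc1ccc(NC(=O)/C=C/c2coc3cc(O)ccc3c2=O)cc1`) returns > 100000 nM, which is a limit of the assay rather than a number. For the measured compounds named here, the one measured step, an at least 4.0-fold lower number from compound 1 to compound 2 (0.60 log units; beyond the scatter), thus puts the benzyl amide ahead of the aryl amide, with compound 1 sitting at the limit of > 100000 nM in this assay, at which 1 of the 2 values shown sits.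

Compound 3 (`O=C(/C=C/c1coc2cc(O)ccc2c1=O)Nc1ccccc1`) is the next candidate. Its change from compound 2 is phenyl in place of 4-methylbenzyl on an amide-type nitrogen. Going by the values given here, this reverses the direction of the one measured step: the aryl ring again sits directly on the amide nitrogen, as in compound 1, though without the methoxy group. Because compound 1 gives > 100000 nM, a move back toward weaker inhibition is expected, of roughly the size seen in an at least 4.0-fold lower number from compound 1 to compound 2 (0.60 log units; beyond the scatter) and with a real chance that only a limit is returned. The estimated step is a 3.2-fold higher number from compound 2 to compound 3 (0.51 log units; beyond the scatter). For compound 3 the expected value in this assay is 80000 nM, with a range from 30000 nM to 200000 nM.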

Compound 3, half-maximal inhibitory concentration: 17900 nM
Beside the measured number, compound 3's estimate is 4.5-fold (0.65 log units) above it; measured number below the stated range.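

In this assay, replacing 4-methylbenzyl with phenyl on the amide-type nitrogen gives a 1.4-fold lower number from compound 2 to compound 3 (0.14 log units; within the scatter), so this pair does not separate an aryl amide from a benzyl amide, and an aryl ring directly on that nitrogen is compatible with a measurable inhibition value. The weak reading of compound 1 therefore tracks with the methoxy group in this pair rather than with the aryl amide as such, as hydrogen in place of methoxy on the aromatic carbon gives an at least 5.5-fold lower number from compound 1 to compound 3 (0.74 log units; beyond the scatter). The true size of that step stays unknown, as compound 1 is a limit of the assay and not a number: the limit of > 100000 nM in this assay, at which 1 of the 3 values shown sits.

Still open, from the compounds shown here alone, is whether the loss seen with methoxy extends to other groups on that aromatic carbon, such as fluorine, chlorine or an amine, and whether methoxy on the benzyl ring of compound 2 would have the same effect. Also open, going by these compounds, is how a longer chain such as phenethyl, or a saturated ring such as cyclohexyl, would read on the amide-type nitrogen in this assay.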